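Swapping tert-butyl for phenyl on a potent binder

A few compounds are considered here, and "the series" means these few. Any claim that something is new, unique, unknown or untested is made for them only; others in the source may bear on it.

Measured so far:
compound 1 `CC(C)(C)c1cc(N)c2cc(NC(=O)/C=C/c3ccc(C(F)(F)F)cc3)ccc2n1` gives 0.3 nM in an assay on isolated protein for displacement of a labelled ligand from melanin-concentrating hormone receptor 1 (Homo sapiens); a higher number here means a weaker inhibitor, a lower number a stronger inhibitor
compound 2 `CCCc1cc(N)c2cc(NC(=O)/C=C/c3ccc(N)cc3)ccc2n1` gives 190 nM in this assay
compound 3 `CCCc1cc(N)c2cc(NC(=O)c3ccc(C(F)(F)F)cc3)ccc2n1` gives 10000 nM in this assay

Compound 1 holds the lowest number of the three, so it is the strongest inhibitor here; compound 2 sits well above it and compound 3 further still, both gaps beyond the usual scatter. The two weaker compounds differ from compound 1 in more than one place at once, so no single change can be read out of them.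

Compound 4 `Nc1cc(-c2ccccc2)nc2ccc(NC(=O)/C=C/c3ccc(C(F)(F)F)cc3)cc12` keeps everything of compound 1 except one group: phenyl in place of tert-butyl on an aromatic carbon. Going by the values given here, no measured pair shows what this kind of swap does on this core, so the expectation rests on compound 1 alone and on the fact that the group sits next to the ring nitrogen. A moderate loss in this assay seems the most likely outcome, though a result within the scatter cannot be ruled out. For compound 4 the expected value is 3 nM, somewhere between 0.3 nM and 30 nM, which would mean an estimated step of a 10-fold higher number from compound 1 to compound 4 (1.00 log units; beyond the scatter).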

Compound 4, half-maximal inhibitory concentration: 18.5 nM
Compound 4: the middle estimate sits 6.2-fold (0.79 log units) below what was measured, and the stated range covers the measured number.
By their numbers in this assay, from the lowest: compound 1; then compound 4; then compound 2; then compound 3.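

Going by these compounds alone, this is the first comparison on the shared core in which only one place changes: phenyl in place of tert-butyl on the aromatic carbon next to the ring nitrogen gives a 62-fold higher number from compound 1 to compound 4 (1.79 log units; beyond the scatter) in this assay. The position is therefore sensitive to the group it carries, although compound 4, with its aromatic ring of carbon only there, still gives 18.5 nM in this assay. Nothing measured here explains why the step is this large.

A single pair cannot separate the effect of having an aromatic ring from that of having more carbon atoms, and cyclohexyl, a saturated ring of six carbons, would help to tell these apart. From the compounds shown here alone, how methyl, a small group, or an amine would fare at this position also remains open.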